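A few compounds are considered here, and "the series" means these few. Any claim that something is new, unique, unknown or untested is made for them only; others in the source may bear on it.

Going by the values given here, compound 1 `COc1cc(C)c(S(=O)(=O)N(C)CCOCC(=O)N2CCN(C3CCN(C4CC4)CC3)CC2)c(C)c1` gives 11.8 10^-6 cm/s in an ADME assay on Caco-2 cells (Homo sapiens) for permeability, tested at 50 uM (on this read-out lower numbers stand for lower permeability and higher numbers for higher permeability), the highest of the two numbers measured so far; compound 2 `COc1cc(C)c(S(=O)(=O)N(C)CCOCC(=O)N2CCC(CN3CCN(C)CC3)CC2)c(C)c1` gives 4.8 10^-6 cm/s in this assay, a gap beyond the scatter. Among the compounds with values here, no two measured compounds differ in only one place, so the step to compound 3 `COc1cc(C)c(S(=O)(=O)N(C)CCOCC(=O)N2CCN(CCN(C)C)CC2)c(C)c1` has no measured counterpart to lean on. Compound 3 differs from compound 1 in this way: 2-(dimethylamino)ethyl in place of 1-cyclopropylpiperidin-4-yl on an amine nitrogen in a ring. For compound 3 a step of a 1.6-fold lower number from compound 1 to compound 3 (0.20 log units; within the scatter) is expected, a modest move downward that could still fall inside the scatter. Compound 3 is therefore estimated at 7.5 10^-6 cm/s, with a likely range from 3 10^-6 cm/s to 17 10^-6 cm/s.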

Compound 3, apparent permeability: 2.1 10^-6 cm/s
The estimate for compound 3 lay 3.6-fold (0.55 log units) above the measured number; measured number below the stated range.
By their numbers in this assay, from the lowest: compound 3; then compound 2; then compound 1.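

On the amine nitrogen in the ring, the group clearly matters: 2-(dimethylamino)ethyl, which has no ring, in place of 1-cyclopropylpiperidin-4-yl gives a 5.6-fold lower number from compound 1 to compound 3 (0.75 log units; beyond the scatter) in this assay and leaves compound 3 lowest of the three. This single step changes group size and ring content together, so it cannot separate the two. Nothing measured here accounts for the drop. From the compounds shown here alone, it remains open whether 1-methylpiperidin-4-yl, which keeps the six-membered ring but lacks the cyclopropyl, or a longer chain such as 3-(dimethylamino)propyl would land nearer compound 1 or compound 3.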